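Replacing the 3-methyl-1,2-oxazol-5-yl group in compound 2

The source may report more compounds than this note shows. Statements on the series, on what has been measured and on what is new or still open speak of the compounds shown alone.

Measured so far in a functional assay on PC-3 cells (Homo sapiens) for cytotoxicity, read by MTT assay, with a stated time of 72 h; on this read-out lower numbers stand for stronger inhibition and higher numbers for weaker inhibition:
- compound 1 `Cc1cc(/C=C/c2ccc(O)cc2)[nH]n1`: 48100 nM
- compound 2 `COc1ccc(/C=C/c2cc(C)no2)cc1OC`: > 100000 nM

For compound 2 the result is a limit and not a number, > 100000 nM. For the measured compounds named here, its true position is therefore unknown, and no step from it can be read from the data. the limit of > 100000 nM in this assay, at which 1 of the 2 values shown sits, is the whole of what is known about its standing.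

The next compound to be tested is compound 3 `COc1ccc(/C=C/C(=O)CC(C)=O)cc1OC`. It carries (2-oxopropyl)carbonyl in place of 3-methyl-1,2-oxazol-5-yl on a double-bonded chain carbon bound to a double-bonded chain carbon. Going by the values given here, the entering group has no ring, and the data hold no measured example of it.

The only numerical anchor in the series is compound 1 at 48100 nM, so the expectation for this assay is placed in that region. A modest step towards stronger inhibition is expected, with a second limit result still possible. The expected change is an at least 2.5-fold lower number from compound 2 to compound 3 (0.39 log units; beyond the scatter), and this is only an estimate. For compound 3 the estimated value is 40000 nM, with an expected range from 12000 nM to 100000 nM.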

Compound 3, half-maximal inhibitory concentration: 8900 nM
The estimate for compound 3 lay 4.5-fold (0.65 log units) above the measured number; measured number below the stated range.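

In this assay, (2-oxopropyl)carbonyl in place of 3-methyl-1,2-oxazol-5-yl on a double-bonded chain carbon bound to a double-bonded chain carbon gives an at least 11-fold lower number from compound 2 to compound 3 (1.05 log units; beyond the scatter), a large change from one group alone. The group at this place thus decides whether the core of compound 2 reads as a number at all, and no ring is needed there: the entering group has no ring, and compound 3 gives 8900 nM. The starting point of this step, compound 2, is a limit and not a number, so the step can be read only as a minimum and its true size stays unknown: the limit of > 100000 nM in this assay, at which 1 of the 3 values shown sits.

With a single entering group at this place, the data cannot tell whether the change in this assay goes with the loss of the ring or with the carbonyl groups of the open chain. For the compounds shown here, also open is how a carboxylic acid or an amine would read at the same place, and compound 1 differs from the other two compounds in more than one place, so no steps to it can be read.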